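The source may hold more compounds than are shown below. What is called first, only, known or untested is meant among the compounds shown, and "the series" means these compounds.

Values in an ADME assay on L02 cells (Homo sapiens) for cytotoxicity, read by MTT assay, with a stated time of 24 h; on this read-out higher numbers stand for weaker inhibition and lower numbers for stronger inhibition:
- compound 1 `O=C1/C(=C/c2ccncc2)CN(S(=O)(=O)c2ccccc2)C/C1=C\c1ccccc1F`: 15900 nM
- compound 2 `O=C1/C(=C/c2ccncc2)CN(S(=O)(=O)c2ccc(F)cc2)C/C1=C\c1ccccc1F`: 15600 nM
- compound 3 `CC(=O)Nc1ccc(S(=O)(=O)N2C/C(=C\c3ccncc3)C(=O)/C(=C/c3ccccc3F)C2)cc1`: not yet measured

For the measured compounds named here, compound 2, at 15600 nM, cannot be separated from the only other measured compound in this assay. Going by the values given here, the single measured step is a 1.0-fold lower number from compound 1 to compound 2 (0.01 log units; within the scatter), which puts fluoro in place of hydrogen on an aromatic carbon and lies within the scatter.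

The next change places acetamido in place of fluoro on an aromatic carbon, para to a large group, turning 4-fluorophenyl into 4-acetamidophenyl: acetamido in place of fluoro on an aromatic carbon. Among the compounds with values here, the measured step is the only evidence on this ring, and it is thin. Within the data shown here, no measured compound carries acetamido, so the data offer no direct measure of this group. Among the measured compounds shown here, since a 1.0-fold lower number from compound 1 to compound 2 (0.01 log units; within the scatter) is the only guide, no shift beyond the scatter is expected in this assay, and no direction is favoured. The expected step is a 1.0-fold higher number from compound 2 to compound 3 (0.01 log units; within the scatter), with a wide margin on either side for the untested group. Compound 3 is estimated at 16000 nM, with an expected range of 7000 nM to 38000 nM.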

Compound 3, half-maximal inhibitory concentration: 12300 nM
Compound 3: middle estimate off by 1.3-fold (0.11 log units), on the high side; the measured number falls inside the stated range.
By their numbers in this assay, from the lowest: compounds 3, 2 and 1 (each within the scatter of the next).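

In this assay, for the compounds shown here, the aromatic carbon para to a large group held only hydrogen or fluoro in the earlier compounds; it now carries acetamido, with 4 heavy atoms, a hydrogen-bond donor and a hydrogen-bond acceptor, and the step from fluoro stays within the scatter (a 1.3-fold lower number from compound 2 to compound 3 (0.10 log units; within the scatter)). The step from hydrogen reads the same way (a 1.3-fold lower number from compound 1 to compound 3 (0.11 log units; within the scatter)), so hydrogen, fluoro and acetamido cannot be told apart at this position on this read-out, and the position accepts a much larger group than fluoro without a shift beyond the scatter. Nothing available here accounts for these steps.

From the compounds shown here alone, all three groups at this position carry no net charge, so it remains open whether an amine or a carboxylic acid here, or a longer chain in place of the acetyl part of acetamido, would move the number beyond the scatter. The rest of the core is the same in compound 1, compound 2 and compound 3, so these compounds say nothing about how the number responds to changes elsewhere.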